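The source may hold more compounds than are shown below. What is called first, only, known or untested is meant among the compounds shown, and "the series" means these compounds.

For the measured compounds named here, compound 1 `Cc1nc(SCC(=O)Nc2nc(-c3ccc(Cl)cc3)cs2)n(Nc2ccccc2)c1C` gives the only measured number in this set: in a functional assay on NCI-H23 cells (Homo sapiens) for antiproliferative activity, read by sulforhodamine B assay, with a stated time of 48 h (a lower number here means that less compound is tolerated, a higher number that more compound is tolerated), compound 1 gives 26300 nM. Compound 2 `Cc1ccc(Nn2c(SCC(=O)Nc3nc(-c4ccccc4)cs3)nc(C)c2C)cc1` reaches only a limit of the assay, and in this assay compound 2 gives > 100000 nM; that limit is the limit of > 100000 nM in this assay, at which 1 of the 2 values shown sits. Compound 3 `COc1ccc(Nn2c(SCC(=O)Nc3nc(-c4ccc(Cl)cc4)cs3)nc(C)c2C)cc1` differs from compound 1 by methoxy in place of hydrogen on an aromatic carbon. Going by the values given here, no measured step covers this change, and compound 2 offers only a limit, so the author expects a step of a 1.3-fold higher number from compound 1 to compound 3 (0.12 log units; within the scatter), at or near the scatter, with a weaker compound 3 somewhat more likely. The expected value for compound 3 in this assay is 35000 nM, between 12000 nM and 100000 nM.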

Compound 3, concentration lethal to 50% of the cells: > 100000 nM
Compound 3: a limit, no number (the forecaster's own chance of this, stated with the estimate: 35%); at least 2.8-fold (0.45 log units) between middle value and limit.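

In this assay, the change from phenyl to 4-methoxyphenyl gives an at least 3.8-fold higher number from compound 1 to compound 3 (0.58 log units; beyond the scatter), so methoxy at this place, para to a large group, moves the read-out beyond the scatter. Compound 3 gives > 100000 nM, which is a limit of the assay and not a number. The step therefore has a lower bound but no measured size: the limit of > 100000 nM in this assay, at which 2 of the 3 values shown sit.

The compounds shown leave open how far past that limit compound 3 lies. They also leave open whether a fluorine or an amine at the same place would give a measurable number.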